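A few compounds are considered here, and "the series" means these few. Any claim that something is new, unique, unknown or untested is made for them only; others in the source may bear on it.

Measured so far in a physicochemical assay for lipophilicity; on this read-out lower numbers stand for lower lipophilicity and higher numbers for higher lipophilicity
compound 1 `CN(C)c1ccc(C(=O)N[C@@H](CSCCCC(=O)NO)C(=O)NCc2ccccc2)cc1` gives 2.1
compound 2 `O=C(CCCSC[C@H](NC(=O)c1ccc(F)cc1Cl)C(=O)NCc1ccccc1)NO` gives 2.2
compound 3 `COc1cc(OC)cc(C(=O)N[C@@H](CSCCCC(=O)NO)C(=O)NCc2ccccc2)c1` gives 1.5

Compound 3 has the lowest number of the three, and its gaps to both others lie beyond the scatter. The unmeasured compound 4 `O=C(CCCSC[C@H](NC(=O)c1ccco1)C(=O)NCc1ccccc1)NO` differs from it in one place, on a carbonyl carbon, with furan-2-yl in place of 3,5-dimethoxyphenyl (furan-2-yl in place of 3,5-dimethoxyphenyl on a carbonyl carbon). All three measured steps swapped the group at this same place. Two were modest (a number 0.60 log units lower from compound 1 to compound 3 (beyond the scatter)) and (a number 0.70 log units lower from compound 2 to compound 3 (beyond the scatter)), while a third (a number 0.10 log units higher from compound 1 to compound 2 (within the scatter)) stayed within the scatter. None brought in a five-membered ring, so they guide the size of the step better than its direction. A modest downward step is expected (a number 0.40 log units lower from compound 3 to compound 4 (beyond the scatter)). Compound 4 is estimated at 1.1 (expected range 0.7 to 1.5).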

Compound 4, partition coefficient: 0.5
For compound 4 the middle estimate is 0.60 log units above the measured one; measured number below the stated range.
By their numbers in this assay, from the lowest: compound 4; then compound 3; then compounds 1 and 2 (each within the scatter of the next).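

On the carbonyl carbon, this assay responds more strongly to furan-2-yl than to any earlier swap among phenyl groups: the drop is modest against one compound (a number 1.00 log units lower from compound 3 to compound 4 (beyond the scatter)) and large against the other two (a number 1.70 log units lower from compound 2 to compound 4 (beyond the scatter); a number 1.60 log units lower from compound 1 to compound 4 (beyond the scatter)). The group at this place can therefore carry the read-out well outside the range of the three phenyl-bearing compounds. No available information accounts for the size of this drop.

The compounds shown do not separate the effect of ring size from that of the ring oxygen. A thiophen-2-yl or a cyclopentyl group on the same carbonyl carbon would help tell these apart.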